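The source may report more compounds than this note shows. Statements on the series, on what has been measured and on what is new or still open speak of the compounds shown alone.

Working notes on the series

Of the compounds shown here, two have numbers so far. Compound 1 `O=C(Cn1nnc(-c2ccccc2)n1)Nc1cc(C2CC2)nn1C1CCCCC1` gives 271 nM in an assay on HEK293 cells for activation of Kir3.1/Kir3.2 (Homo sapiens), read by thallium flux; on this read-out higher numbers stand for an effect only at larger amounts of compound and lower numbers for an effect already at smaller amounts. Compound 2 `Cc1cc(NC(=O)Cn2nnc(-c3cccnc3)n2)n(C2CCCCC2)n1` gives 1930 nM in this assay, the highest of the two numbers shown; compound 1 sits at the lower number, and the gap between the two is beyond the scatter. Among the measured compounds shown here, compound 1 and compound 2 differ in two places at once, so their two values show only that the pair as a whole differs and cannot be read as a single step for either change.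

Compound 3 `Cc1cc(NC(=O)Cn2nnc(-c3ccc(Cl)c(Cl)c3)n2)n(C2CCCCC2)n1` has not been measured. It differs from compound 2 in one place: 3,4-dichlorophenyl in place of pyridin-3-yl on an aromatic carbon. No measured pair in the series isolates this change, so any expectation rests on compound 2 alone as the starting point and on the general spread the series has shown. The step from compound 2 to compound 3 is expected as a 3.2-fold lower number from compound 2 to compound 3 (0.51 log units; beyond the scatter), toward a lower number, and beyond the scatter. For compound 3 the estimate in this assay is 600 nM, with a range from 150 nM to 2500 nM.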

Compound 3, half-maximal effective concentration: 1220 nM
Compound 3: the middle estimate sits 2.0-fold (0.31 log units) below what was measured; the measured number falls inside the stated range.
By their numbers in this assay, from the lowest: compound 1; then compounds 3 and 2 (each within the scatter of the next).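

In this assay, among the compounds shown here, the exchange of pyridin-3-yl for 3,4-dichlorophenyl on an aromatic carbon of the five-membered aromatic ring with 4 nitrogen is the first single-place step, and it gives a 1.6-fold lower number from compound 2 to compound 3 (0.20 log units; within the scatter). At this position, then, the loss of the ring nitrogen, which is the one hydrogen-bond acceptor of pyridin-3-yl, and the entry of two chlorine atoms on a carbon-only aromatic ring leave the two compounds within the scatter of each other, so this one exchange does not separate them on this read-out. Nothing at hand speaks to the reason for this result.

For the compounds shown here, compound 1 differs from each of the other two compounds in two places, so no step to it can be read, and the part played by cyclopropyl against methyl, or by phenyl against the other aromatic groups, stays open. Also open, as far as these compounds go, is whether this position responds at all to a group of another kind, such as a carboxylic acid or a morpholine, on the aromatic ring or in its place.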